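The source may report more compounds than this note shows. Statements on the series, on what has been measured and on what is new or still open speak of the compounds shown alone.

Compound 1 `COc1ccc(CCCc2ccc(OC)cc2OC)c(O)c1`: 97.7%
Compound 2 `COc1ccc(/C=C/C(=O)c2ccc(OC)c(OC)c2)cc1`: 93.1%
Compound 3 `COc1ccc(/C=C/C(=O)c2ccc(OC)c(OC)c2)cc1OC`: 91.9%

Of the compounds shown here, three have been measured in an ADME assay on RAW264.7 cells (Mus musculus) for cytotoxicity, read by MTT assay, with a stated time of 24 h, tested at 2.5 ug/mL (on this read-out lower numbers stand for a stronger effect and higher numbers for a weaker effect at the one concentration tested), and all three give numbers within the scatter of one another, so no order among them can be read from this assay. Compound 1 and compound 3 rest on different cores; the difference between the two cores is not broken down here. Compound 3 and compound 2, by contrast, differ in one place, (hydrogen in place of methoxy on an aromatic carbon), and that step is a number 1.2 percentage points higher from compound 3 to compound 2 (within the scatter).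

Compound 4 `COc1ccc(CCCc2ccc(OC)cc2O)cc1` has not yet been measured. It arises from compound 1 by hydrogen in place of methoxy on an aromatic carbon. Among the measured compounds shown here, this is the same kind of change as the one from compound 3 to compound 2, but not the same: in the measured pair the place is ortho to a methoxy group and meta to a large group, whereas in compound 1 it is ortho to a large group and meta to a methoxy group.

Because the measured step of a number 1.2 percentage points higher from compound 3 to compound 2 (within the scatter) stayed within the scatter, the step of a number 1.7 percentage points lower from compound 1 to compound 4 (within the scatter) is expected to be small as well. Compound 4 is therefore estimated at 96% in this assay, within 88% and 102%.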

Compound 4, a percentage reported as activity, at one concentration (the size of the read-out at that concentration, not a potency): 96.8%
Beside the measured number, compound 4's estimate is 0.8 percentage points below it; low and high end bracket the measured number.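

In this assay, hydrogen in place of methoxy on an aromatic carbon gives a number 0.9 percentage points lower from compound 1 to compound 4 (within the scatter), a step that can be set directly beside the earlier one. The two steps do not differ from one core to the other: the same change on two cores in this assay, a number 1.2 percentage points higher (within the scatter) from compound 3 to compound 2 and a number 0.9 percentage points lower (within the scatter) from compound 1 to compound 4, 2.1 percentage points apart, within the scatter of two such steps. This shows that the change carries across these two cores without a step beyond the scatter in this read-out at the one concentration tested, but it rests on just two pairs, with the change at a different place in each, and since neither step has a size beyond the scatter, no effect of the change has been shown to carry over.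

The compounds shown leave open what happens when the methoxy gives way to something other than hydrogen, such as an amine, a carboxylic acid or a longer alkoxy chain. They also leave open whether any such group would give a number in this assay that stands apart from the others, on either core.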